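A few compounds are considered here, and "the series" means these few. Any claim that something is new, unique, unknown or untested is made for them only; others in the source may bear on it.

Of the compounds shown here, two have numbers so far. Compound 1 `O=C(O)C[C@H](O)C[C@H](O)CCn1c(-c2ccc(F)cc2)nc(C(=O)NCc2ccc(F)c(F)c2)c1C1CC1` gives 1.2 nM in an assay on microsomes from liver for inhibition of 3-hydroxy-3-methylglutaryl-coenzyme A reductase (Rattus norvegicus), read by scintillation counting, with stated times of 0.5 h and 0.75 h; on this read-out higher numbers stand for weaker inhibition and lower numbers for stronger inhibition. Going by the values given here, compound 2 `Cc1cccc(CNC(=O)c2nc(-c3ccc(F)cc3)n(CC[C@@H](O)C[C@@H](O)CC(=O)O)c2C2CC2)c1` gives 7.2 nM in this assay, the higher of the two numbers; the one measured step, a 6.0-fold higher number from compound 1 to compound 2 (0.78 log units; beyond the scatter), lies beyond the scatter and separates compound 2 from its nearest neighbour, compound 1.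

The next compound, compound 3 `O=C(O)C[C@H](O)C[C@H](O)CCn1c(-c2ccc(F)cc2)nc(C(=O)NCc2ccc(F)cc2)c1C1CC1`, is compound 2 with one change: 4-fluorophenyl in place of 3-methylphenyl on a saturated chain carbon bound to an amide-type nitrogen. Among the compounds with values here, only the step from compound 1 to compound 2 bears on it, since it moves the same part of the molecule, and it was modest in size. Compound 3 carries a single fluorine on that ring where compound 1 carries two and compound 2 carries none, so it is expected to sit between them, with the number moving back toward that of compound 1 rather than matching it. The expected step is therefore a fall of a 2.9-fold lower number from compound 2 to compound 3 (0.46 log units; beyond the scatter) in this assay, beyond the scatter but short of the full measured step. On that basis compound 3 is estimated at 2.5 nM in this assay, within a range from 1 nM to 6 nM.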

Compound 3, half-maximal inhibitory concentration in the 3-hydroxy-3-methylglutaryl-coenzyme A reductase assay: 3.4 nM
Compound 3: middle estimate off by 1.4-fold (0.13 log units), on the low side; low and high end bracket the measured number.
By their numbers in the 3-hydroxy-3-methylglutaryl-coenzyme A reductase assay, from the lowest: compound 1; then compound 3; then compound 2.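

In the 3-hydroxy-3-methylglutaryl-coenzyme A reductase assay the 4-fluorophenyl group gives a stronger inhibitor than the 3-methylphenyl group at this place (a 2.1-fold lower number from compound 2 to compound 3 (0.33 log units; beyond the scatter)), so this change does not depend on keeping the 3,4-difluorophenyl group of compound 1. Hydrogen in place of fluoro on an aromatic carbon also counts on this ring (a 2.8-fold higher number from compound 1 to compound 3 (0.45 log units; beyond the scatter)), and the three groups now read in order from the 3,4-difluorophenyl group through the 4-fluorophenyl group to the 3-methylphenyl group, each step beyond the scatter. In a physicochemical assay for lipophilicity, using the shake flask method, at pH 7.4 (a lower number here means a more polar compound, a higher number a more lipophilic compound), compound 2 gives 0.47 and compound 3 gives 0.17 (a number 0.30 log units lower from compound 2 to compound 3 (within the scatter)), so these two compounds separate in the 3-hydroxy-3-methylglutaryl-coenzyme A reductase assay while remaining within the scatter of each other on this second read-out.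

No available finding accounts for the differences in inhibition among these ring groups.

Open, going by these compounds, is how a chloro, methoxy or nitrile group on this ring, or a longer chain in place of the single saturated carbon bound to the amide-type nitrogen, would read in the 3-hydroxy-3-methylglutaryl-coenzyme A reductase assay.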